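Benzofuran to naphthalene on the amide of compound 3

The compounds below may be only part of what the source reports. "The series", "measured", "known", "first", "only" and "open" are said of these compounds alone.

Compound 1, `CN(C)CCCOc1ccc(CN2CC[C@H](NC(=O)c3ccco3)C2)cc1`: in an assay on HEK293 cells for binding affinity to Urotensin-2 receptor (Homo sapiens), read by radioligand binding (on this read-out lower numbers stand for stronger inhibition and higher numbers for weaker inhibition), compound 1 gives < 10000 nM, which is a limit of the assay and not a number.
Compound 2, `CC(=O)N[C@H]1CCN(Cc2ccc(OCCCN(C)C)cc2)C1`: in this assay compound 2 gives < 10000 nM, again a limit of the assay.
Compound 3, `CN(C)CCCOc1ccc(CN2CC[C@H](NC(=O)c3cc4ccccc4o3)C2)cc1`: in this assay compound 3 gives 2510 nM.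

Within the data shown here, compound 3 thus holds the only number among the three values; the other two sit at the limit of < 10000 nM in this assay, at which 2 of the 3 values shown sit. The steps that reach compound 3 are unreadable: a step that the limit leaves unreadable from compound 1 to compound 3 and a step that the limit leaves unreadable from compound 2 to compound 3. The limits leave their size unread. Compound 4, `CN(C)CCCOc1ccc(CN2CC[C@H](NC(=O)c3ccc4ccccc4c3)C2)cc1`, differs from compound 3 by naphthalen-2-yl in place of 1-benzofuran-2-yl on a carbonyl carbon. Among the measured compounds shown here, no measured step in this assay reads a size for an exchange of one aromatic system for another on this carbonyl carbon, so no direction beyond the scatter can be drawn from the data. Compound 4 is therefore expected to sit near compound 3, at an estimated 2000 nM with a range of 500 nM to 8000 nM. That estimate amounts to an expected step of a 1.3-fold lower number from compound 3 to compound 4 (0.10 log units; within the scatter).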

Compound 4, inhibition constant: < 10000 nM
Compound 4: a limit, no number (the forecaster's own chance of this, stated with the estimate: 25%); the middle value lies beyond the limit too.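

Compound 4 gives a limit of the assay and no number, so its steps from compound 1, compound 2 and compound 3 cannot be read: the limit of < 10000 nM in this assay, at which 3 of the 4 values shown sit. The compounds shown leave open the size and direction of the change when naphthalen-2-yl replaces 1-benzofuran-2-yl on the carbonyl carbon.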